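The source may hold more compounds than are shown below. What is called first, only, known or untested is meant among the compounds shown, and "the series" means these compounds.

Three compounds built on one shared core have been run through a functional assay on TREX cells for negative allosteric modulation of metabotropic glutamate receptor 3 (Rattus norvegicus), read by calcium flux, with a stated time of 2.5 min; on this read-out lower numbers stand for stronger inhibition and higher numbers for weaker inhibition. Compound 1 `COc1ccc(C#Cc2ccc(C(=O)N3CCC[C@@H](CO)C3)cc2)c(F)c1` gives only a limit there, > 10000 nM. Compound 3 `O=C(c1ccc(C#Cc2ccc(O)cc2)cc1)N1CCC[C@@H](CO)C1` likewise returns only a limit, > 10000 nM. Among the measured compounds shown here, compound 2 `COc1ccc(C#Cc2ccc(C(=O)N3CCCC(OC)C3)cc2)cc1` is the single compound with an actual number, 5500 nM, so among the three it stands as the one readable value. The change from compound 1 to compound 3 touches only the group on the triple-bonded carbon, yet a step that the two limits leave unreadable from compound 1 to compound 3 cannot be sized, because both of its ends are at the limit of > 10000 nM in this assay, at which 2 of the 3 values shown sit.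

Compound 4 `COc1ccc(C#Cc2ccc(C(=O)N3CC4CCC(=O)C4C3)cc2)cc1` has not been measured. It differs from compound 2 at the amide end: a group of 9 heavy atoms (7 carbon, 1 nitrogen, 1 oxygen; one five-membered non-aromatic ring of carbon only, one five-membered non-aromatic ring with 1 hetero atom) in place of a group of 8 heavy atoms (6 carbon, 1 nitrogen, 1 oxygen; one six-membered non-aromatic ring with 1 hetero atom), on a carbonyl carbon. For the measured compounds named here, no measured step changes this part of the molecule; the only measured step lies at the far end and is itself unreadable, so the data offer no direction for this change. The expected step is therefore one within the usual scatter, a 1.1-fold higher number from compound 2 to compound 4 (0.04 log units; within the scatter), with wide uncertainty. There is also a real chance that compound 4 returns only a limit. Compound 4 is accordingly estimated at 6000 nM, between 1500 nM and 20000 nM.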

Compound 4, half-maximal inhibitory concentration: 2750 nM
Estimate against measurement, compound 4: 2.2-fold (0.34 log units) above, and the stated range covers the measured number.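

Measured in this assay, replacing the 3-methoxypiperidin-1-yl group on the carbonyl carbon gives a 2.0-fold lower number from compound 2 to compound 4 (0.30 log units; within the scatter). Among the compounds shown here, this is the first direct look at the amide end of the molecule, and it shows that a larger group with two five-membered rings can stand in place of the single six-membered ring without a change that rises beyond the scatter, with the count of hydrogen-bond donors and acceptors left unchanged. It is also the only step in the set with a readable size, because the step from compound 1 to compound 3 cannot be read, with both of its ends resting on a limit and not on a number: the limit of > 10000 nM in this assay, at which 2 of the 4 values shown sit.

A single step within the scatter cannot show which feature of the amide group matters, or whether any change there could move the number beyond the scatter. As far as these compounds go, a basic amine or a carboxylic acid on the amide-end group would test this position with something quite different from the neutral groups in compound 2 and compound 4, and the effect of either remains open.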